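The source may report more compounds than this note shows. Statements on the series, on what has been measured and on what is new or still open speak of the compounds shown alone.

Measured in a functional assay on SW1990 cells (Homo sapiens) for antiproliferative activity, read by MTT assay, with a stated time of 96 h; on this read-out higher numbers stand for weaker inhibition and lower numbers for stronger inhibition:
- compound 1 `COc1c(O)cc2cc1C[C@H](C)C[C@H](OC)[C@H](O)[C@@H](C)/C=C(\C)C[C@H](OC(N)=O)[C@@H](OC)CC/C=C(\C)C(=O)N2`: 3710 nM
- compound 2 `COc1ccc([C@H]2c3cccc(c3O)NC(=O)/C(C)=C/C=C\[C@H](OC)[C@@H](OC(N)=O)/C(C)=C/[C@H](C)[C@@H](O)[C@@H](OC)C[C@@H]2C)cc1`: 800 nM

Compound 2, at 800 nM, holds the lower of the two numbers, and the gap to compound 1 lies beyond the scatter. Compound 3 `COc1ccc([C@H]2c3cccc(c3O)NC(=O)/C(C)=C/C=C\[C@H](OC)[C@@H](OC(N)=O)/C(C)=C/[C@H](C)[C@@H](OC)[C@@H](OC)C[C@@H]2C)cc1` is not yet measured. It differs from compound 2 by methyl in place of hydrogen on an oxygen on a saturated carbon, or hydroxy to methoxy. For the measured compounds named here, no measured pair differs in one place, so the data offer no direct precedent for this change, and the expectation is a judgement with wide margins. In this assay, a modest move towards weaker inhibition is expected, only slightly beyond the scatter. The estimated change is a 1.9-fold higher number from compound 2 to compound 3 (0.27 log units; within the scatter). For compound 3 the expected value is 1500 nM, with an estimated range from 500 nM to 5000 nM.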

Compound 3, half-maximal inhibitory concentration: 3370 nM
For compound 3 the middle estimate is 2.2-fold (0.35 log units) below the measured one, within the range that was stated.
By their numbers in this assay, from the lowest: compound 2; then compounds 3 and 1 (each within the scatter of the next).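

In this assay, for the compounds shown here, hydroxy to methoxy on the saturated carbon gives a 4.2-fold higher number from compound 2 to compound 3 (0.62 log units; beyond the scatter) and is the first step that differs in one place. This position is therefore not indifferent to methyl in place of hydrogen, and of the two groups compared here, the free hydroxy gives the stronger inhibition, although this rests on a single pair on one core. No measurement available here accounts for the weaker inhibition of compound 3.

Going by these compounds, whether a larger ether such as ethoxy, an acetate ester or an amine at this oxygen-bearing carbon would track with hydroxy or methoxy remains open. Also open, on these data alone, is whether the same change gives a step of similar size on the core of compound 1.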